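From furan-2-yl to phenyl at the assay limit

The compounds below may be only part of what the source reports. "The series", "measured", "known", "first", "only" and "open" are said of these compounds alone.

In a functional assay on K562 cells (Homo sapiens), read by MTT assay, with a stated time of 72 h (on this read-out lower numbers stand for stronger inhibition and higher numbers for weaker inhibition), compound 1 (`CSc1ncnc2c1c(-c1cccs1)cn2[C@@H]1O[C@H](CO)[C@@H](O)[C@H]1O`) gives > 20000 nM as a limit and not a number. Compound 2 (`Nc1nc(N)c2c(-c3ccco3)cn([C@@H]3O[C@H](CO)[C@@H](O)[C@H]3O)c2n1`) gives > 20000 nM as a limit. Compound 3 (`COc1nc(N)nc2c1c(-c1ccco1)cn2[C@@H]1O[C@H](CO)[C@@H](O)[C@H]1O`) gives > 20000 nM as a limit, so it sits with the other two (the limit of > 20000 nM in this assay, at which 3 of the 3 values shown sit). Within the data shown here, the only measured step (a step that the two limits leave unreadable from compound 2 to compound 3) has no readable size. Compound 4 (`COc1nc(N)nc2c1c(-c1ccccc1)cn2[C@@H]1O[C@H](CO)[C@@H](O)[C@H]1O`) carries phenyl in place of furan-2-yl on an aromatic carbon. No measured step sizes this change, so in this assay no step beyond the scatter and no direction is expected. The expected step (a number no higher from compound 3 to compound 4 (the limit leaves the size open)) is an estimate only. For compound 4 the estimated value is 20000 nM (expected range 7000 nM to 40000 nM) and another limit reading is likely.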

Compound 4, half-maximal inhibitory concentration: > 20000 nM
Compound 4: no number, only a limit; the forecaster's own chance of this, stated with the estimate: 85%; the middle value lies on the limit itself.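

No step can be read from compound 3 to compound 4, because both stand only as limits: the limit of > 20000 nM in this assay, at which 4 of the 4 values shown sit. The compounds shown leave open which change on the shared core, if any, would give a measurable number.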